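The source may report more compounds than this note shows. Statements on the series, on what has been measured and on what is new or still open speak of the compounds shown alone.

For the measured compounds named here, compound 2, `COc1ccc(C2(O)/C(=C/c3ccc(C)cc3)CCCC2CN(C)c2ccc(C)cc2)cc1`, stands highest of the two numbers so far in a functional assay on the whole organism (Ear, strain Kunming) for inhibition, with Mus musculus as the target, with stated times of 1 h and 30 min, at a dose of 200 mg/kg by the oral route (a lower number here means less inhibition, a higher number more inhibition at the dose given (going by the name of the read-out)), where compound 2 gives 29.9%. Going by the values given here, its only neighbour is compound 1, `COc1ccc(C2(O)/C(=C/c3ccc(C)cc3)CCCC2CN(C)c2ccccc2)cc1`, which in this assay gives 16.3%. Among the compounds with values here, the one measured step, a number 13.6 percentage points higher from compound 1 to compound 2 (beyond the scatter), adds a methyl to an aromatic carbon and is the only guide available. Compound 3, `COc1ccc(C2(O)/C(=C/c3ccc(C)cc3)CCCC2CN(C)c2cccc(C)c2)cc1`, is not yet measured; its difference from compound 2 is 3-methylphenyl in place of 4-methylphenyl on an amine nitrogen. Within the data shown here, no measured step moves a methyl from one place on the ring to another, so there is no direct precedent for this change, and the measured step shows only that the methyl itself brought a modest rise. The step expected here, a number 4.9 percentage points lower from compound 2 to compound 3 (within the scatter), is small and may well fall within the scatter. Compound 3 is therefore estimated to give 25% in this assay, with a likely range from 12% to 38%.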

Compound 3, a percentage reported as inhibition, in the whole organism at one dose (the size of the read-out at that dose, not a potency): 24.5%
The estimate for compound 3 lay 0.5 percentage points above the measured number, within the range that was stated.
By their numbers in this assay, from the lowest: compounds 1, 3 and 2 (each within the scatter of the next, the first and the last beyond it).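

Moving the methyl, with 3-methylphenyl in place of 4-methylphenyl on the amine nitrogen, gives a number 5.4 percentage points lower from compound 2 to compound 3 (within the scatter) in this assay, so the two placements cannot be told apart here. Adding a methyl to reach the 3-methylphenyl group gives a number 8.2 percentage points higher from compound 1 to compound 3 (within the scatter), so compound 3 cannot be told apart from compound 1 either, although compound 2 does stand clear of compound 1, with a number 13.6 percentage points higher from compound 1 to compound 2 (beyond the scatter). The data offer no explanation for these results.

From the compounds shown here alone, it remains open whether an ethyl group, a methoxy group or a chlorine atom on this ring would behave as the methyl does. Also open, going by these compounds, is what would happen if a longer chain replaced the methyl on the amine nitrogen.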